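Three Sulfonamides at the Assay Ceiling, a Fourth Predicted

The compounds below may be only part of what the source reports. "The series", "measured", "known", "first", "only" and "open" are said of these compounds alone.

Compound 1 `O=S(=O)(Nc1ccc(-c2nc3ccccc3o2)cc1)c1cccc(F)c1` gives only a limit, > 63000 nM, in an assay on isolated protein for inhibition of malate dehydrogenase, mitochondrial (Sus scrofa), with stated times of 45 min and 30 min; a lower number here means a stronger inhibitor, a higher number a weaker inhibitor.
Compound 2 `Cc1ccccc1S(=O)(=O)Nc1ccc2oc(-c3ccccc3)nc2c1` gives only a limit, > 63000 nM, in this assay.
Compound 3 `O=S(=O)(Nc1ccc2oc(-c3ccccc3)nc2c1)c1ccc(F)c(C(F)(F)F)c1` gives only a limit, > 63000 nM, in this assay.

Compound 2 therefore stands nowhere in particular on a scale of potency: its value is a limit, not a number, and the same holds for every value shown, since (the limit of > 63000 nM in this assay, at which 3 of the 3 values shown sit). Among the measured compounds shown here, no compound here has a measured step to another, so no size of change has been observed.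

Compound 4 `O=S(=O)(Nc1ccc2oc(-c3ccccc3)nc2c1)c1ccc(Cl)cc1` differs from compound 2 in a single place: 4-chlorophenyl in place of 2-methylphenyl on a sulfonyl sulfur. Three compounds of this kind with different substituents on the sulfonyl sulfur all failed to reach a measurable inhibition, and nothing in the data points to the 4-chlorophenyl group changing that. The step from compound 2 to compound 4 is expected to be none beyond the scatter, which is to say a step that the limit leaves unreadable from compound 2 to compound 4. Compound 4 is accordingly expected to give about 100000 nM in this assay, within a range from 20000 nM to 500000 nM, most likely again as a limit rather than a number.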

Compound 4, half-maximal inhibitory concentration: > 63000 nM
Compound 4: only a limit was reported (the forecaster's own chance of this, stated with the estimate: 85%); the middle value is on the limit's open side.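

Compound 2 and compound 4 both give only a limit, so the swap of 2-methylphenyl for 4-chlorophenyl yields no readable step: the limit of > 63000 nM in this assay, at which 4 of the 4 values shown sit.

The compounds shown leave open whether any compound of this kind gives a measurable value in this assay, and which change might produce one.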